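This account rests on a few compounds, and the source may have more. Where it says the series, first, only, none or still open, it means among the compounds named here.

Of the compounds shown here, two have so far been tested in a functional assay on corpus cavernosum (Rattus norvegicus) for activation; on this read-out higher numbers stand for larger maximal responses and lower numbers for smaller maximal responses. Compound 1 `CC(C)Oc1ccccc1-c1nc2c(cnn2-c2ccccc2)c(=O)[nH]1` gives 130% there. Compound 2 `Nc1ccccc1NCc1nc2c(cnn2-c2ccccc2)c(=O)[nH]1` gives 113% in this assay, the lower of the two results, and its gap to compound 1 lies beyond the usual scatter. Compound 3 `O=c1[nH]c(CNc2ccccc2O)nc2c1cnn2-c1ccccc1` is still unmeasured and differs from compound 2 in one place: hydroxy in place of amino on an aromatic carbon. For the measured compounds named here, no measured pair shows this change, so no step size can be read from the data. In this assay a step of about a number 2 percentage points higher from compound 2 to compound 3 (within the scatter) is expected, which is no clear movement beyond the scatter. Compound 3 is therefore estimated to give 115%, within a range from 95% to 135%.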

Compound 3, largest response reached (Emax), in percent of the reference or control that the assay uses: 125%
The estimate for compound 3 lay 10 percentage points below the measured number; low and high end bracket the measured number.
By their numbers in this assay, from the lowest: compound 2; then compounds 3 and 1 (each within the scatter of the next).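

Hydroxy in place of amino on this aromatic carbon, ortho to a large group, is the only one-place change that can be read here, and in this assay it brings a number 12 percentage points higher from compound 2 to compound 3 (beyond the scatter). The maximal response is therefore sensitive to this swap, although the two groups have the same counts of heavy atoms, hydrogen-bond donors and hydrogen-bond acceptors. Nothing available explains the step. From the compounds shown here alone, what a methoxy group or a plain hydrogen would do at this position remains open.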